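The compounds below may be only part of what the source reports. "The series", "measured", "known", "first", "only" and "open" are said of these compounds alone.

Compound 1 `COc1cc(NC(=O)/C=C/c2cccc(OCc3ccccc3)c2)cc(OC)c1OC`: 17300 nM
Compound 2 `C=C(Br)C(=O)Nc1cccc(/C=C/C(=O)Nc2ccccc2)c1`: 190 nM

In a functional assay on CCRF-CEM cells (Homo sapiens) for inhibition, read by MTT assay, with a stated time of 72 h (on this read-out lower numbers stand for stronger inhibition and higher numbers for weaker inhibition), compound 2 holds the lower of the two numbers, and its gap to compound 1 lies beyond the scatter. Compound 3 `C=C(Br)C(=O)Nc1cccc(/C=C/C(=O)Nc2ccc(C)cc2)c1` departs from compound 2 in one place: methyl in place of hydrogen on an aromatic carbon. This puts methyl in place of hydrogen on an aromatic carbon, para to a large group. For the measured compounds named here, no measured pair shows this change, so the expectation rests on its small size. The step expected is a 1.2-fold higher number from compound 2 to compound 3 (0.06 log units; within the scatter), which would be none beyond the scatter in this assay. Compound 3 is estimated at 220 nM, with an expected range from 90 nM to 550 nM.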

Compound 3, half-maximal inhibitory concentration: 270 nM
The estimate for compound 3 lay 1.2-fold (0.09 log units) below the measured number, and the stated range covers the measured number.
By their numbers in this assay, from the lowest: compounds 2 and 3 (each within the scatter of the next); then compound 1.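

In this assay, methyl in place of hydrogen on an aromatic carbon, para to a large group, gives a 1.4-fold higher number from compound 2 to compound 3 (0.15 log units; within the scatter) and so leaves the number unchanged within the scatter. For the compounds shown here, this is the first single-place comparison, and it shows that this position accepts one added methyl without a step beyond the scatter. Nothing measured here offers an explanation for this outcome. Still open, from the compounds shown here alone, is whether a carboxylic acid, an amine or a longer chain at this same position would also stay within the scatter of compound 2.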